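The compounds below may be only part of what the source reports. "The series", "measured", "known", "first", "only" and "open" are said of these compounds alone.

In a functional assay on K562 cells (Homo sapiens) for antiproliferative activity, read by MTT assay, with a stated time of 72 h (on this read-out lower numbers stand for stronger inhibition and higher numbers for weaker inhibition), two compounds sharing one core have been measured so far. Among the measured compounds shown here, compound 1 `CCCCCCCC(=O)Oc1cc(C(=O)C2=C3OC(C)(C)[C@@H](CC=C(C)C)C[C@@]34C[C@@H](CC=C(C)C)C(C)(C)[C@H]3CCC(C)(C)O[C@]34OC2=O)ccc1O` gives 15300 nM, the only actual number available. Compound 2 `CC(C)=CC[C@H]1C[C@]23C[C@@H](CC=C(C)C)C(C)(C)[C@H]4CCC(C)(C)O[C@]42OC(=O)C(C(=O)c2ccc(OC(=O)c4ccc(F)cc4)c(OC(=O)c4ccc(F)cc4)c2)=C3OC1(C)C` reads > 20000 nM, which is a limit of the assay and not a number. Compound 1 is therefore the sole numerical reference point, and it sits on the weak side of the measurable range.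

The next compound is compound 3 `CC(C)=CC[C@H]1C[C@]23C[C@@H](CC=C(C)C)C(C)(C)[C@H]4CCC(C)(C)O[C@]42OC(=O)C(C(=O)c2ccc(O)c(O)c2)=C3OC1(C)C`, which differs from compound 1 by a single change: hydrogen in place of heptylcarbonyl on an oxygen on an aromatic ring. In words, this puts hydrogen in place of heptylcarbonyl on an oxygen on an aromatic ring, so that (heptylcarbonyl)oxy becomes hydroxy. For the measured compounds named here, no step between measured compounds is available to gauge this change. In this assay, a moderate move towards stronger inhibition, beyond the usual scatter, is nevertheless expected, as the reading of compound 1 at 15300 nM leaves most room in that direction. The expected change is a 3.1-fold lower number from compound 1 to compound 3 (0.49 log units; beyond the scatter). For compound 3 the estimated value is 5000 nM, with an expected range of 1500 nM to 16000 nM.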

Compound 3, half-maximal inhibitory concentration: 7690 nM
Compound 3: middle estimate off by 1.5-fold (0.19 log units), on the low side; measured number inside the range.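

In this assay, the change on this oxygen on an aromatic ring comes to a 2.0-fold lower number from compound 1 to compound 3 (0.30 log units; within the scatter), so taking off the heptylcarbonyl and leaving a hydroxy does not shift the reading beyond the usual scatter of repeated measurements. Among the compounds shown here, this is the first step that can be read at this place, and it shows that, on the shared core, the long ester and the free hydroxy cannot be told apart on this read-out, so the heptylcarbonyl can be removed here with no clear gain or loss in inhibition. The compounds shown offer no measured property that would account for this step, and no reason for it can be given.

On these data alone, it remains open whether a short acyl group such as acetyl, a methyl ether or an aromatic acyl group such as 4-fluorobenzoyl, placed on this oxygen alone, would read the same or move the number beyond the scatter. Also open, as far as these compounds go, is whether an amine or a carboxylic acid at this place on the aromatic ring would bring a clear change in either direction.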